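The source may report more compounds than this note shows. Statements on the series, on what has been measured and on what is new or still open speak of the compounds shown alone.

Measured so far in a functional assay on MV4-11 cells (Homo sapiens) for inhibition, read by resazurin assay, with a stated time of 72 h; a lower number here means a stronger inhibitor of growth, a higher number a weaker inhibitor of growth:
compound 2 `CNc1nc(C)c(-c2ccnc(Nc3ccc(OC)cc3OC)n2)s1` — 300 nM
compound 1 `COc1ccc(Nc2nccc(-c3c[nH]c4ccccc34)n2)c(OC(F)F)c1` — 4770 nM

Of the two numbers in this assay, compound 2 holds the lower one; compound 1 stands a long way above it, a gap beyond the scatter. Among the compounds with values here, no pair of measured compounds differing in a single place is available, so there is no direct precedent for the change examined here.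

Compound 3 `CCOc1nc(C)c(-c2ccnc(Nc3ccc(OC)cc3OC)n2)s1` is next to be measured in this assay. It differs from compound 2 in one place: ethoxy in place of methylamino on an aromatic carbon. The count of heavy atoms barely moves, but the hydrogen-bond donor on that ring carbon is lost. Within the data shown here, with no such pair to lean on, the step expected for compound 3 is a 3.3-fold higher number from compound 2 to compound 3 (0.52 log units; beyond the scatter), towards a higher number, of a size beyond the scatter yet well short of the gap to compound 1. For compound 3 the estimate is 1000 nM, in the range 300 nM to 4000 nM.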

Compound 3, concentration for 50% growth inhibition: 3890 nM
Compound 3: middle estimate off by 3.9-fold (0.59 log units), on the low side, and the stated range covers the measured number.
By their numbers in this assay, from the lowest: compound 2; then compounds 3 and 1 (each within the scatter of the next).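

In this assay, within the data shown here, ethoxy in place of methylamino on the aromatic carbon next to the ring nitrogen and next to the ring sulfur gives a 13-fold higher number from compound 2 to compound 3 (1.11 log units; beyond the scatter) and provides the first direct reading at this position. Growth inhibition in this pair is therefore sensitive to the group on this carbon, with the methylamino of compound 2 giving the lower number. The change removes the hydrogen-bond donor and also replaces the nitrogen-linked group with an oxygen-linked one, and no measurement on hand bears on the reason for the step.

Ethylamino, methoxy and a plain amino group on this carbon remain open. Until such groups are seen, the contributions of the donor, the linking atom and the chain cannot be separated.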